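From methoxy to acetamido on a sulfur side chain

This account rests on a few compounds, and the source may have more. Where it says the series, first, only, none or still open, it means among the compounds named here.

Of the compounds shown here, three have numbers so far in a functional assay on HeLa cells (Homo sapiens) for cytotoxicity, read by resazurin assay, with a stated time of 72 h (on this read-out higher numbers stand for weaker inhibition and lower numbers for stronger inhibition), as the measure. Compound 2 (`COCCSC(=S)SCC(=O)c1ccc(OC)cc1`) gives 7880 nM and compound 3 (`CCSC(=S)SCC(=O)c1ccc(C(=O)NCc2ccccc2)s1`) gives 13000 nM on it, a gap that lies within the usual scatter, so these two cannot be told apart. Compound 1 (`CCOC(=S)SCC(=O)c1ccc(NC(C)=O)cc1`) gives 3610 nM on the same read-out, a lower number than compound 2 shows, and that gap lies beyond the scatter. Compound 2 therefore stands alongside compound 3 in the higher-number group of this small set.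

The change from compound 2 to compound 4 (`COc1ccc(C(=O)CSC(=S)SCCNC(C)=O)cc1`), which has not yet been measured, reads acetamido in place of methoxy on a saturated chain carbon, two bonds along the chain from a sulfur and puts acetamido in place of methoxy on a saturated chain carbon, two bonds along the chain from a sulfur. For the measured compounds named here, no pair of measured compounds differs in one place only, so there is no direct precedent for this swap. Compound 1 also carries an acetamido group, at a different place and with other differences, so its 3610 nM is only a weak hint toward a lower number. The step of a 1.1-fold lower number from compound 2 to compound 4 (0.05 log units; within the scatter) is therefore expected to stay within the scatter. In this assay compound 4 is estimated at 7000 nM with an expected range from 2500 nM to 20000 nM for repeat measurements.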

Compound 4, half-maximal inhibitory concentration: 11100 nM
Beside the measured number, compound 4's estimate is 1.6-fold (0.20 log units) below it; the measured number falls inside the stated range.
By their numbers in this assay, from the lowest: compound 1; then compounds 2, 4 and 3 (each within the scatter of the next).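

For the compounds shown here, this is the first pair in the set that differs in one place only, so the swap of methoxy for acetamido on a saturated chain carbon, two bonds along the chain from a sulfur, can now be read directly. In this assay the swap gives a 1.4-fold higher number from compound 2 to compound 4 (0.15 log units; within the scatter) and so shows that this place takes the larger acetamido group, with the hydrogen-bond donor that methoxy lacks, without a change this read-out can resolve. No measurement shown here speaks to why the number behaves this way.

Going by these compounds alone, whether an amine, a carboxylic acid or a longer chain at this same place would move the number beyond the scatter remains open, since methoxy and acetamido are the only two groups compared here and a single pair cannot define what this place tolerates. As far as these compounds go, the swap has also been read on one core only, so it is unknown whether the same exchange would give a similarly small step on the core of compound 1 or on the core of compound 3.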